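The source may report more compounds than this note shows. Statements on the series, on what has been measured and on what is new or still open speak of the compounds shown alone.

In a functional assay on MCF7 cells (Homo sapiens) for cytotoxicity, read by MTT assay (a higher number here means a weaker inhibitor, a lower number a stronger inhibitor), compound 1 (`CC(=O)O[C@@H]1OC(=O)[C@](C)(C(C)=O)[C@@H]1C`) gives 6000 nM, compound 2 (`CC(=O)[C@@]1(C)C(=O)O[C@@H](OC(=O)C(C)(C)C)[C@H]1C`) gives 3000 nM and compound 3 (`CC(=O)[C@@]1(C)C(=O)O[C@@H](OC(=O)c2ccccc2)[C@H]1C`) gives 3000 nM. Compound 2 stands level with compound 3, and neither is separated from compound 1 beyond the scatter.

The next change leads to compound 4 (`CCO[C@@H]1OC(=O)[C@](C)(C(C)=O)[C@@H]1C`): ethyl in place of (tert-butyl)carbonyl on an oxygen on a saturated carbon, with ethyl in place of (tert-butyl)carbonyl on an oxygen on a saturated carbon.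

For the measured compounds named here, three measured steps bear on this change: a 2.0-fold lower number from compound 1 to compound 2 (0.30 log units; within the scatter), a 2.0-fold lower number from compound 1 to compound 3 (0.30 log units; within the scatter) and no change at the digits printed from compound 2 to compound 3 (within the scatter). All three stay within the scatter, so the group on the carbonyl carbon has shown little effect on the numbers in this assay across these compounds. However, each of them keeps the carbonyl, whereas compound 4 lacks it at this oxygen, so these steps give only indirect guidance and the range must stay wide. No step beyond the scatter is expected, with any drift towards a higher number.

The estimated step is a 2.0-fold higher number from compound 2 to compound 4 (0.30 log units; within the scatter). For compound 4 the expected value is 6000 nM, with an estimated range of 2000 nM to 20000 nM.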

Compound 4, half-maximal inhibitory concentration: > 50000 nM
Compound 4 was reported as a limit (the forecaster's own chance of this, stated with the estimate: 10%); at least 8.3-fold (0.92 log units) between middle value and limit.
By their numbers in this assay, from the lowest: compounds 2, 3 and 1 (each within the scatter of the next). At a limit, above all of these: compound 4.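

Compound 4 stands at a limit in this assay, not at a number: the limit of > 50000 nM in this assay, at which 1 of the 4 values shown sits.

Ethyl in place of (tert-butyl)carbonyl on an oxygen on a saturated carbon gives an at least 16-fold higher number from compound 2 to compound 4 (1.22 log units; beyond the scatter), and ethyl in place of acetyl at the same place gives an at least 8.3-fold higher number from compound 1 to compound 4 (0.92 log units; beyond the scatter). The steps among compounds 1, 2 and 3 all keep the carbonyl on this oxygen and stay within the scatter, so in the compounds shown, the group on the carbonyl carbon has shown little effect, while the change that removes the carbonyl leaves the scatter.

Open, on these data alone, is whether a longer chain such as butyl, or a free hydroxyl, on this oxygen would sit with compound 4. Also open, as far as these compounds go, is whether a carbamate, with an amine on the carbonyl carbon, would stay with compounds 1, 2 and 3.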